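The source may report more compounds than this note shows. Statements on the series, on what has been measured and on what is new or still open speak of the compounds shown alone.

Measured so far in a functional assay on the whole organism (Tail, strain ICR) with Mus musculus as the target, in the tail flick test, with a stated time of 90 min, at a dose of 25 umol/kg by the oral route; a higher number here means a stronger effect of the compound at the dose given, a lower number a weaker effect:

compound 1, `O=C(O)[C@@H]1CCCN1C(=O)CN(c1nc(Cl)nc2[nH]cnc12)C1CC1`: 26%
compound 2, `O=C(CN(c1ncnc2c1ncn2C1CCCCO1)C1CC1)NCC(=O)OCc1ccccc1`: 25.9%
compound 3, `CC[C@H](C)[C@H](NC(=O)CN(c1nc(Cl)nc2[nH]cnc12)C1CC1)C(=O)O`: 27.4%

All three numbers lie within the usual scatter of one another, so compound 1 cannot be set apart from compound 2 or compound 3 on these values; compound 2 is the nearest to it, compound 3 the furthest, and neither gap exceeds the scatter.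

Compound 4, `O=C(OCc1ccccc1)[C@@H]1CCCN1C(=O)CN(c1nc(Cl)nc2[nH]cnc12)C1CC1`, is not yet measured in this assay. It differs from compound 1 in one place: benzyl in place of hydrogen on an oxygen next to a carbonyl group. Going by the values given here, no measured pair shows this change on its own. Compound 2 carries the same benzyloxycarbonyl group and gives a number close to compound 1, which gives no reason to expect a shift in either direction. The step of no change at the digits printed from compound 1 to compound 4 (within the scatter) is therefore expected to stay within the scatter. For compound 4 the expected value is 26%, with a range from 12% to 42%.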

Compound 4, a percentage reported as activity, at one dose (the size of the read-out at that dose, not a potency): 43.3%
Compound 4: the middle estimate sits 17.3 percentage points below what was measured; measured number outside the range, above it.
By their numbers in this assay, from the lowest: compounds 2, 1 and 3 (each within the scatter of the next); then compound 4.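

Carboxy to benzyloxycarbonyl gives, in this assay, a number 17.3 percentage points higher from compound 1 to compound 4 (beyond the scatter) and is the first single-place step in the series to show a change at this position. Going by these compounds alone, the oxygen next to the carbonyl group is therefore a place where substitution alters the read-out at this dose, which the earlier compounds, with no pair between them, could not show.

Going by these compounds, whether the benzyl ring is needed, or a methyl or ethyl on the same oxygen would give a similar step, remains open. No measurement shown accounts for the step.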